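Sulfonate aryl swap on the not-active compound 3

The compounds below may be only part of what the source reports. "The series", "measured", "known", "first", "only" and "open" are said of these compounds alone.

Measured in a functional assay on HL-60 cells (Homo sapiens) for inhibition, read by CCK-8 assay, with a stated time of 48 h, tested at 20 uM; a higher number here means more inhibition of growth at the concentration tested, a lower number less inhibition of growth:
- compound 1 `COc1ccc(Cc2nnc(NC(=O)/C(C#N)=C/c3ccccc3OS(=O)(=O)c3ccc(C)cc3)s2)cc1`: 25%
- compound 2 `N#C/C(=C\c1ccccc1OS(=O)(=O)c1ccccc1[N+](=O)[O-])C(=O)Nc1nnc(Cc2ccccc2)s1`: 12%
- compound 3 `Cc1ccc(S(=O)(=O)Oc2ccccc2/C=C(\C#N)C(=O)Nc2nnc(Cc3ccc(F)cc3)s2)cc1`: "not active" (no number reported)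

Among the measured compounds shown here, compound 3 is reported as "not active" (no number reported), with no number, so it has no exact place on the numerical scale and no step from it can be sized. Compound 4 `N#C/C(=C\c1ccccc1OS(=O)(=O)c1ccccc1[N+](=O)[O-])C(=O)Nc1nnc(Cc2ccc(F)cc2)s1` has not yet been measured. The structural change is 2-nitrophenyl in place of 4-methylphenyl on a sulfonyl sulfur, with 2-nitrophenyl in place of 4-methylphenyl on a sulfonyl sulfur.

For the measured compounds named here, no measured pair isolates this change, so the expectation is tentative. A small upward step in this assay is expected, probably not beyond the usual scatter. Going by the values given here, the only support is compound 2, which also carries (2-nitrophenyl)sulfonyl and gives 12%. A second report without a number would not be surprising.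

For compound 4 an inhibition of 12% is estimated, with an expected range of 0% to 28%.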

Compound 4, percent growth inhibition at one concentration: 35%
For compound 4 the middle estimate is 23 percentage points below the measured one, outside the stated range (above it).
By their numbers in this assay, from the lowest: compound 2; then compounds 1 and 4 (each within the scatter of the next).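

In this assay compound 4 gives 35% while compound 3, with (4-methylphenyl)sulfonyl in place of (2-nitrophenyl)sulfonyl, has no number, so the step between them cannot be read, though this swap on the sulfonyl sulfur separates a "not active" report from a measured inhibition. Fluoro in place of hydrogen on an aromatic carbon gives a number 23 percentage points higher from compound 2 to compound 4 (beyond the scatter) and is the first sized step in the series, yet compound 3 carries the same fluoro and has no number, so fluoro alone does not secure a reading. Nothing measured here explains either change.

From the compounds shown here alone, whether the fluoro step also holds with (4-methylphenyl)sulfonyl remains open. Also open, going by these compounds, is how an amine or a carboxylic acid in place of the nitro group would read.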